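Swapping an iodophenyl tail for a pyridyl tail

This account rests on a few compounds, and the source may have more. Where it says the series, first, only, none or still open, it means among the compounds named here.

Measured so far in a functional assay on 1321-N1 cells for agonist activity at P2Y purinoceptor 6 (Homo sapiens), read by scintillation counting and inositol phosphate accumulation; on this read-out lower numbers stand for an effect already at smaller amounts and higher numbers for an effect only at larger amounts of compound:
Compound 1 `O=c1[nH]/c(=N\OCCCCc2ccccc2)ccn1[C@@H]1O[C@H](COP(=O)(O)OP(=O)(O)OP(=O)(O)O)[C@@H](O)[C@H]1O` gives 251 nM.
Compound 2 `O=c1[nH]/c(=N\OCCCc2cccc(I)c2)ccn1[C@@H]1O[C@H](COP(=O)(O)OP(=O)(O)OP(=O)(O)O)[C@@H](O)[C@H]1O` gives 299 nM.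
Compound 3 `O=c1[nH]/c(=N\OCCCc2ccc(I)cc2)ccn1[C@@H]1O[C@H](COP(=O)(O)OP(=O)(O)OP(=O)(O)O)[C@@H](O)[C@H]1O` gives 90 nM.

Compound 3 has the lowest number of the three; its steps to the others, a 2.8-fold lower number from compound 1 to compound 3 (0.45 log units; beyond the scatter) and a 3.3-fold lower number from compound 2 to compound 3 (0.52 log units; beyond the scatter), both lie beyond the scatter, while a 1.2-fold higher number from compound 1 to compound 2 (0.08 log units; within the scatter) does not. Compound 4 `O=c1[nH]/c(=N\OCCCc2cccnc2)ccn1[C@@H]1O[C@H](COP(=O)(O)OP(=O)(O)OP(=O)(O)O)[C@@H](O)[C@H]1O` differs from compound 3 in one place: pyridin-3-yl in place of 4-iodophenyl on a saturated chain carbon, three bonds along the chain from an oxygen. Within the data shown here, no measured step removes the iodine and brings in a ring nitrogen, so only the gain on going to the 4-iodophenyl group offers guidance; losing that group may give part of it back. Compound 4 is therefore expected to show a 3.3-fold higher number from compound 3 to compound 4 (0.52 log units; beyond the scatter), an estimate of 300 nM with a range from 100 nM to 900 nM.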

Compound 4, half-maximal effective concentration: 2950 nM
The estimate for compound 4 lay 9.8-fold (0.99 log units) below the measured number; measured number above the stated range.
By their numbers in this assay, from the lowest: compound 3; then compounds 1 and 2 (each within the scatter of the next); then compound 4.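

In this assay, putting pyridin-3-yl at this place raises the number well beyond the scatter against every earlier tail (a 33-fold higher number from compound 3 to compound 4 (1.52 log units; beyond the scatter); a 9.9-fold higher number from compound 2 to compound 4 (0.99 log units; beyond the scatter); a 12-fold higher number from compound 1 to compound 4 (1.07 log units; beyond the scatter)). Among these compounds, these steps exceed any seen among the earlier compounds, so this place does not treat all six-membered aromatic rings alike. Nothing shown gives a reason for the rise.

From the compounds shown here alone, compound 4 loses the iodine and gains a ring nitrogen together, so their separate shares remain open. A plain phenyl at this place, or pyridin-4-yl, would help to separate them.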